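The compounds below may be only part of what the source reports. "The series", "measured", "known", "first", "only" and "open" are said of these compounds alone.

Measured so far in an in vitro assay on Sf9 cells for inhibition of 17-beta-hydroxysteroid dehydrogenase type 1 (Homo sapiens), tested at 100 nM; on this read-out higher numbers stand for a stronger effect at the one concentration tested and lower numbers for a weaker effect:
- compound 1, `O=C(c1c(O)ccc2cc(-c3cccc(O)c3)ccc12)N1CCOCC1`: 28%
- compound 2, `O=C(Nc1ccccc1)c1cc2cc(-c3cccc(O)c3)ccc2cc1O`: 17%

Among the compounds with values here, compound 1 holds the higher of the two numbers in this assay; the only neighbour, compound 2, sits lower by a gap beyond the usual scatter. Within the data shown here, no pair differing in one place has been measured, so nothing is known yet about how the acylated position tolerates change.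

Compound 3, `CNC(=O)/C=C/c1c(O)ccc2cc(-c3cccc(O)c3)ccc12`, is the next to be measured in this assay. Against compound 1 it differs as follows: 2-(methylcarbamoyl)ethenyl in place of (morpholin-4-yl)carbonyl on an aromatic carbon. The change sits on an aromatic carbon of the shared core, ortho to a hydroxy group and ortho to a fused ring.

Among the measured compounds shown here, with no measured step to lean on, the expected step from compound 1 to compound 3 in this assay is a number 3 percentage points lower from compound 1 to compound 3 (within the scatter), that is, none beyond the scatter in either direction. The estimate for compound 3 in this assay is therefore 25%, with a wide range from 5% to 50%.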

Compound 3, a percentage reported as inhibition, at one concentration (the size of the read-out at that concentration, not a potency): 19%
Compound 3: the middle estimate sits 6 percentage points above what was measured; the range from low to high includes it.
By their numbers in this assay, from the lowest: compounds 2, 3 and 1 (each within the scatter of the next, the first and the last beyond it).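

In this assay the read-out gives a number 9 percentage points lower from compound 1 to compound 3 (within the scatter), the first step available at this aromatic carbon, ortho to a hydroxy group and ortho to a fused ring. The change removes the six-membered non-aromatic ring of (morpholin-4-yl)carbonyl and brings in the ringless 2-(methylcarbamoyl)ethenyl with its hydrogen-bond donor, yet the step stays within the scatter, so this one exchange of a ring for an open chain leaves no readable trace at the concentration tested. No available evidence bears on this result.

Still open, on these data alone, is how an amine, a carboxylic acid or a longer chain on this carbon would read in this assay. Also open, as far as these compounds go, is whether the ethenyl link and the methylcarbamoyl end would each hold up alone.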